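Dimethoxy substitution on the arylidene of compound 1

The source may hold more compounds than are shown below. What is called first, only, known or untested is meant among the compounds shown, and "the series" means these compounds.

Compound 1 `O=C1N=C(NN2Cc3ccccc3N=C2c2ccccc2)S/C1=C/c1ccccc1` is one of three compounds tested in a functional assay on MCF7 cells (Homo sapiens) for cytotoxicity, read by MTT assay, with a stated time of 4 h (a lower number here means a stronger inhibitor, a higher number a weaker inhibitor), in which compound 1 gives 4050 nM. Its companions share a different core: compound 2 `O=C(CNc1ccc(Cl)cc1Cl)Nn1c(-c2ccccc2)nc2ccccc2c1=O` gives 4410 nM and compound 3 `CCc1ccc(NCC(=O)Nn2c(-c3ccccc3)nc3ccccc3c2=O)cc1` gives 2420 nM. All three numbers lie within the scatter of one another, so compound 1 is neither set apart from compound 2 nor from compound 3. Going by the values given here, the only single-point step among them, a 1.8-fold lower number from compound 2 to compound 3 (0.26 log units; within the scatter), is an aryl swap on an amine nitrogen and stays within the scatter.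

Compound 4 `COc1ccc(/C=C2/SC(NN3Cc4ccccc4N=C3c3ccccc3)=NC2=O)cc1OC` is not yet measured. It differs from compound 1 in one place: 3,4-dimethoxyphenyl in place of phenyl on a double-bonded chain carbon bound to a double-bonded ring carbon. Among the compounds with values here, no measured step touches this position or this core, and the one step that exists, between compound 2 and compound 3, shows that an aryl swap elsewhere left the number within the scatter. Compound 4 is therefore expected to give about 3500 nM, within 1500 nM to 9000 nM, an expected step of a 1.2-fold lower number from compound 1 to compound 4 (0.06 log units; within the scatter) that does not clearly exceed the scatter.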

Compound 4, half-maximal inhibitory concentration: 1000 nM
Compound 4: the middle estimate sits 3.5-fold (0.54 log units) above what was measured, and the stated range ends above it.
By their numbers in this assay, from the lowest: compound 4; then compounds 3, 1 and 2 (each within the scatter of the next).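

In this assay, 3,4-dimethoxyphenyl in place of phenyl on a double-bonded chain carbon bound to a double-bonded ring carbon brings a 4.1-fold lower number from compound 1 to compound 4 (0.61 log units; beyond the scatter), so this position of the core of compound 1 does respond to substitution on the aryl group. Going by these compounds alone, the earlier compounds could not show this: their only step, a 1.8-fold lower number from compound 2 to compound 3 (0.26 log units; within the scatter), belongs to another core and another place. The entering group differs from phenyl by its two methoxy groups and its 2 hydrogen-bond acceptors, but no measurement here explains the step.

The compounds shown leave open whether a single methoxy group would give the same step, and which of the two methoxy groups matters more. They also leave open how a hydroxyl group, a chlorine or a dimethylamino group on this aryl ring would compare.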